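The source may report more compounds than this note shows. Statements on the series, on what has been measured and on what is new or still open speak of the compounds shown alone.

Of the compounds shown here, three sharing one core have been tested in a functional assay on CHO cells for agonist activity at Free fatty acid receptor 1 (Homo sapiens), read by FLIPR, tested at 100 nM; a lower number here means a weaker effect, a higher number a stronger effect of the compound at the concentration tested. Compound 1 `Cc1ccc(OCC(=O)Nc2ccc(OCC(=O)O)c(F)c2)cc1` gives 31.2% in this assay, compound 2 `CCc1ccc(OCC(=O)Nc2ccc(OCC(=O)O)c(F)c2)cc1` gives 14.6%, and compound 3 `CC(C)c1ccc(OCC(=O)Nc2ccc(OCC(=O)O)c(F)c2)cc1` gives 11.8%. Compound 2 therefore stands second highest of the three numbers; its nearest neighbour is compound 3, within the scatter, and its furthest is compound 1, beyond the scatter.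

Compound 4 `COc1cccc(OCC(=O)Nc2ccc(OCC(=O)O)c(F)c2)c1` has not yet been measured. It differs from compound 2 in one place: 3-methoxyphenyl in place of 4-ethylphenyl on an oxygen on a saturated carbon. Of the measured steps, the closest in spirit are those that alter the group on the same aromatic ring, namely a number 16.6 percentage points lower from compound 1 to compound 2 (beyond the scatter), a number 19.4 percentage points lower from compound 1 to compound 3 (beyond the scatter) and a number 2.8 percentage points lower from compound 2 to compound 3 (within the scatter). Within the data shown here, each of these lengthens a carbon chain, whereas the change to compound 4 swaps a 4-ethylphenyl for a 3-methoxyphenyl, which no measured step mirrors. The two larger measured steps were modest and downward; the third lay within the scatter. The expectation is therefore a step of a number 5.4 percentage points higher from compound 2 to compound 4 (within the scatter) in this assay, which may well fall within the scatter. Compound 4 is estimated at 20% in this assay, with a range from 6% to 40%.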

Compound 4, a percentage reported as activity, at one concentration (the size of the read-out at that concentration, not a potency): 31.7%
For compound 4 the middle estimate is 11.7 percentage points below the measured one; the measured number falls inside the stated range.
By their numbers in this assay, from the lowest: compounds 3 and 2 (each within the scatter of the next); then compounds 1 and 4 (each within the scatter of the next).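

In this assay, among these compounds, putting 3-methoxyphenyl in place of 4-ethylphenyl on the oxygen gives a number 17.1 percentage points higher from compound 2 to compound 4 (beyond the scatter), the first upward step beyond the scatter in this small set, so the read-out at this position can recover as well as fall. Set against the 4-methylphenyl group, the same 3-methoxyphenyl gives a number 0.5 percentage points higher from compound 1 to compound 4 (within the scatter), so the two groups cannot be told apart here, even though they differ both in what is on the ring and in the number in the group's name. Nothing available here explains the rise seen with the 3-methoxyphenyl group.

Among the compounds shown, the methoxy group and its place on the ring change together, so it stays open which of the two carries the step; a 4-methoxyphenyl or a 3-methylphenyl group would pull them apart. From the compounds shown here alone, it also stays open whether a longer ether such as 3-ethoxyphenyl, or a ring bearing an amine, would hold this level, and since the read-out comes from a single concentration, it says nothing directly about potency.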